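The source may hold more compounds than are shown below. What is called first, only, known or untested is meant among the compounds shown, and "the series" means these compounds.

Measured so far:
compound 1 `Cn1c(=O)c(S(=O)(=O)c2ccc([N+](=O)[O-])cc2F)cc2cnc(Nc3ccc4[nH]ccc4c3)nc21`: 200 nM
compound 2 `O=c1[nH]c2nc(Nc3ccc4[nH]ccc4c3)ncc2cc1S(=O)(=O)c1ccc(F)cc1F`: 15000 nM

Going by the values given here, in a functional assay on K562 cells (Homo sapiens) for inhibition, read by trypan blue exclusion, with a stated time of 72 h (on this read-out lower numbers stand for stronger inhibition and higher numbers for weaker inhibition), compound 1 stands at the lower of the two numbers, and compound 2 lies beyond the scatter above it; the two structures differ in more than one place, so no single step is defined between them. Compound 3 `Cn1c(=O)c(S(=O)(=O)c2ccc(F)cc2N)cc2cnc(Nc3ccc4[nH]ccc4c3)nc21` is not yet measured and differs from compound 1 in one place: 2-amino-4-fluorophenyl in place of 2-fluoro-4-nitrophenyl on a sulfonyl sulfur. Among the compounds with values here, no measured step of this kind exists in the set, so the expectation rests on compound 1 alone. A small shift toward weaker inhibition is expected, a 2.0-fold higher number from compound 1 to compound 3 (0.30 log units; within the scatter), within reach of the scatter. Compound 3 is estimated at 400 nM, with a range of 100 nM to 2000 nM.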

Compound 3, half-maximal inhibitory concentration: 2000 nM
For compound 3 the middle estimate is 5.0-fold (0.70 log units) below the measured one, and the stated range covers the measured number.
By their numbers in this assay, from the lowest: compound 1; then compound 3; then compound 2.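

Going by these compounds alone, on the sulfonyl sulfur, the aryl group matters in this assay: 2-amino-4-fluorophenyl in place of 2-fluoro-4-nitrophenyl gives a 10-fold higher number from compound 1 to compound 3 (1.00 log units; beyond the scatter), the first single-place step. This change moves more than one substituent on the ring, so the step cannot be assigned to the loss of the nitro group or to the gain of the amino group alone. Nothing available bears on the cause of this shift.

As far as these compounds go, it remains open how compound 1 would compare with a nitrile or a methoxy group in place of its nitro group.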